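From compound 3 to compound 4: a reshaped amine chain

This account rests on a few compounds, and the source may have more. Where it says the series, first, only, none or still open, it means among the compounds named here.

Measured in a functional assay on K562 cells (Homo sapiens) for antiproliferative activity, read by MTT assay, with a stated time of 48 h; a higher number here means a weaker inhibitor, a lower number a stronger inhibitor:
- compound 1 `CCn1c(N)c(-c2nc3ccccc3[nH]2)c2nc(C#N)c(C#N)nc21`: > 50000 nM (a limit)
- compound 2 `CCN(CC)CCn1c(N)c(-c2nc3ccccc3[nH]2)c2nc(C#N)c(C#N)nc21`: 2490 nM
- compound 3 `CCN(CC)CCn1c(N)c(-c2nc3ccccc3n2C)c2nc(C#N)c(C#N)nc21`: > 50000 nM (a limit)

For compound 3, this assay reports only a limit, > 50000 nM. It therefore stands at the limit of > 50000 nM in this assay, at which 2 of the 3 values shown sit, and no number fixes its place.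

Compound 4 `CN(C)CCCCn1c(N)c(-c2nc3ccccc3n2C)c2nc(C#N)c(C#N)nc21` has the same atoms as compound 3, joined differently: 2-(dimethylamino)ethyl in place of diethylamino on a saturated chain carbon, two bonds along the chain from an aromatic nitrogen. In words, 2-(dimethylamino)ethyl comes in place of diethylamino on a saturated chain carbon, two bonds along the chain from an aromatic nitrogen. Cut one bond further out, the same difference reads 2-(diethylamino)ethyl to 4-(dimethylamino)butyl. The methyl on the aromatic nitrogen stays.

Two large measured steps, both beyond the scatter, bear on this change, though neither tests it directly. The chain step is an at least 20-fold lower number from compound 1 to compound 2 (1.30 log units; beyond the scatter). The methyl step is an at least 20-fold higher number from compound 2 to compound 3 (1.30 log units; beyond the scatter), and compound 4 keeps that methyl, so the expectation follows the second step. The expected step is a number no higher from compound 3 to compound 4 (the limit leaves the size open), which means none beyond the scatter, and another limit reading is likely. For compound 4 the estimated value in this assay is 50000 nM, with an expected range from 15000 nM to 100000 nM.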

Compound 4, half-maximal inhibitory concentration: 1450 nM
Estimate against measurement, compound 4: 34-fold (1.54 log units) above; the whole stated range lies above it.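

In this assay, moving the same atoms into a different chain gives an at least 34-fold lower number from compound 3 to compound 4 (1.53 log units; beyond the scatter), so the methyl on the aromatic nitrogen does not by itself rule out a measurable value. The earlier compounds shown here showed that methyl only with the 2-(diethylamino)ethyl chain, whereas compound 4 shows that, with the methyl kept, the form of the amine chain at this position decides whether a number can be read at all, as compound 4 gives 1450 nM. The reading for compound 3 is a limit, so the true size of the step stays open: the limit of > 50000 nM in this assay, at which 2 of the 4 values shown sit.

The compounds shown do not separate the longer chain from the exchange of diethylamino for dimethylamino, since 2-(diethylamino)ethyl and 4-(dimethylamino)butyl differ in both at once, with the same count of heavy atoms. Also open, on these data alone, is how a 4-(diethylamino)butyl chain, a 2-(dimethylamino)ethyl chain or a piperidine at the chain end would read with the methyl in place, and how 4-(dimethylamino)butyl would read with hydrogen on that aromatic nitrogen.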